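Chloro for Methoxy on the Saturated Ring Carbon

The source may report more compounds than this note shows. Statements on the series, on what has been measured and on what is new or still open speak of the compounds shown alone.

Compound 1 `COc1cccc(C2CC(c3cc(OC)c(OC)c(OC)c3)=NN2C(C)=O)c1` belongs to a small set of acetylated five-membered cores bearing two aryl groups. In a functional assay on B16 cells (Mus musculus) for cytotoxicity, read by MTT assay, with a stated time of 72 h (on this read-out lower numbers stand for stronger inhibition and higher numbers for weaker inhibition), compound 1 gives only a limit, > 100000 nM. That limit marks the edge of the measurement rather than a number, so compound 1 stands at the weak end of everything shown, as the limit of > 100000 nM in this assay, at which 1 of the 2 values shown sits, records. Among the compounds with values here, its companion, compound 2 `COc1ccc(OC)c(C2=NN(C(C)=O)C(c3ccc(OC)c([N+](=O)[O-])c3)C2)c1`, is the one member with a numerical result: in this assay compound 2 gives 58000 nM, itself a weak outcome. Within the data shown here, no step between these two is set out; they differ in more than one place, and their values show only that neither reaches strong inhibition.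

Compound 3 `COc1cc(C2=NN(C(C)=O)C(c3ccc(Cl)cc3)C2)cc(OC)c1OC` has not yet been measured. It departs from compound 1 by one change, (4-chlorophenyl in place of 3-methoxyphenyl on a saturated ring carbon), on a saturated ring carbon next to the ring nitrogen. With compound 1 known only as a limit, no size can be fixed for the measured step, and any real movement beyond the scatter is expected to be small. Compound 3 is estimated at 60000 nM, within a range from 20000 nM to 200000 nM. The expected step is an at least 1.6-fold lower number from compound 1 to compound 3 (0.22 log units; that floor lies within the scatter).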

Compound 3, half-maximal inhibitory concentration: 35000 nM
For compound 3 the middle estimate is 1.7-fold (0.23 log units) above the measured one; low and high end bracket the measured number.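

On the saturated ring carbon next to the ring nitrogen, 4-chlorophenyl in place of 3-methoxyphenyl gives, in this assay, an at least 2.8-fold lower number from compound 1 to compound 3 (0.45 log units; beyond the scatter). Within the data shown here, this is the first step that can be read on the shared core, since the two earlier compounds differ in more than one place, and it shows that the aryl group on this carbon can move the read-out beyond the scatter, although compound 3 at 35000 nM still stands far from strong inhibition. The step can be given only as a floor, because the value of compound 1 is a limit: the limit of > 100000 nM in this assay, at which 1 of the 3 values shown sits.

The exchange removes the methoxy group and brings in a chlorine at once, so the compounds shown leave open whether the step belongs to the loss of the one, the arrival of the other, or the different ring position each occupies on the phenyl group. They also leave open what a plain phenyl, a 4-fluorophenyl or a 4-aminophenyl group would give on this same carbon, and whether any such group would bring the series nearer to strong inhibition.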